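The source may hold more compounds than are shown below. What is called first, only, known or untested is meant among the compounds shown, and "the series" means these compounds.

Series values in an assay on isolated protein for binding affinity to histone acetyltransferase KAT2B (Homo sapiens), read by fluorescence, tested at 10 uM; on this read-out higher numbers stand for stronger stabilisation of the target against heat and lower numbers for weaker stabilisation of the target:
compound 1 `CN1C[C@H](Nc2nc3cc[nH]c3c(=O)n2C)C[C@H](c2cccc(Br)c2)C1`: 7.5 degrees C
compound 2 `CN1C[C@H](Nc2nc3cc[nH]c3c(=O)n2C)C[C@H](c2ccccc2)C1`: 6.3 degrees C
compound 3 `CN1C[C@H](Nc2nc3cc[nH]c3c(=O)n2C)C[C@H](c2ccc(OC(F)(F)F)cc2)C1`: 5.9 degrees C

Compound 3 gives the lowest of the three numbers, but it sits within the scatter of compound 2; only compound 1 stands clearly higher. Compound 4 `COc1ccc([C@H]2C[C@@H](Nc3nc4cc[nH]c4c(=O)n3C)CN(C)C2)cc1` carries methyl in place of trifluoromethyl on an oxygen on an aromatic ring. Going by the values given here, no measured step covers this exact exchange. The nearest guidance is a number 0.40 degrees C lower from compound 2 to compound 3 (within the scatter), which shows that putting trifluoromethoxy onto the ring changed little, while a number 1.2 degrees C lower from compound 1 to compound 2 (beyond the scatter) shows a modest loss on removing bromo. Replacing trifluoromethyl by methyl on the oxygen is therefore expected to give no step beyond the scatter in this assay, at most a slight rise toward compound 2, namely a number 0.30 degrees C higher from compound 3 to compound 4 (within the scatter). Compound 4 is estimated at 6.2 degrees C, between 5 degrees C and 7.4 degrees C.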

Compound 4, shift of the target's melting temperature: 8 degrees C
For compound 4 the middle estimate is 1.8 degrees C below the measured one; measured number above the stated range.
By their numbers in this assay, from the lowest: compounds 3 and 2 (each within the scatter of the next); then compounds 1 and 4 (each within the scatter of the next).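

On the oxygen on the aromatic ring, the group carried there matters in this assay: methyl in place of trifluoromethyl gives a modest gain (a number 2.1 degrees C higher from compound 3 to compound 4 (beyond the scatter)), and methoxy in place of hydrogen also registers (a number 1.7 degrees C higher from compound 2 to compound 4 (beyond the scatter)), which trifluoromethoxy did not. The 4-methoxyphenyl in place of 3-bromophenyl stays level (a number 0.50 degrees C higher from compound 1 to compound 4 (within the scatter)). No evidence at hand accounts for this difference between the two oxygen-bound groups. 

Open, as far as these compounds go, is whether a longer chain on the oxygen, such as ethyl, keeps this level. Also open, from the compounds shown here alone, is how a hydroxyl or an amine on the ring would read.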